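Chain extension on the ester side chain: solubility notes

This account rests on a few compounds, and the source may have more. Where it says the series, first, only, none or still open, it means among the compounds named here.

Compound 1 `CC(=O)Oc1cc(OC(C)=O)c2c(=O)c(OC(C)=O)c(-c3ccc(OC(C)=O)c(OC(=O)[C@@H](C)NC(=O)OC(C)(C)C)c3)oc2c1` and compound 2 `CC(=O)Oc1cc(OC(C)=O)c2c(=O)c(OC(C)=O)c(-c3ccc(OC(C)=O)c(OC(=O)CCCNC(=O)OC(C)(C)C)c3)oc2c1` share the same core and differ only in the acyl group on one ester. In a physicochemical assay for solubility, with a stated time of 24 h (a lower number here means a less soluble compound, a higher number a more soluble compound), compound 1 gives 12000 nM, while compound 2 gives 2500 nM. Going by the values given here, the one recorded step, a 4.8-fold lower number from compound 1 to compound 2 (0.68 log units; beyond the scatter), shows that replacing the branched 1-((tert-butoxycarbonyl)amino)ethyl by the longer 3-((tert-butoxycarbonyl)amino)propyl went with a lower number. Among the compounds with values here, on the two numbers so far, compound 2 stands lowest, with compound 1 as its only neighbour, a higher number away and beyond the scatter.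

Compound 3 `CC(=O)Oc1cc(OC(C)=O)c2c(=O)c(OC(C)=O)c(-c3ccc(OC(C)=O)c(OC(=O)CCCCCNC(=O)OC(C)(C)C)c3)oc2c1` carries the change (2-((tert-butoxycarbonyl)amino)ethyl in place of (tert-butoxycarbonyl)amino on a saturated chain carbon, three bonds along the chain from a carbonyl carbon); read one bond further out, it amounts to 3-((tert-butoxycarbonyl)amino)propyl becoming a five-carbon chain bearing the same terminal group. Within the data shown here, no measured step reproduces this exact lengthening; only the step from compound 1 to compound 2 bears on it, and that step was modest and downward. The expectation for compound 3 is therefore a further modest step downward, a 2.1-fold lower number from compound 2 to compound 3 (0.32 log units; beyond the scatter), within this assay. Compound 3 is estimated at 1200 nM, with a range of 400 nM to 4000 nM.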

Compound 3, solubility: 3900 nM
Estimate against measurement, compound 3: 3.3-fold (0.51 log units) below; low and high end bracket the measured number.
By their numbers in this assay, from the lowest: compounds 2 and 3 (each within the scatter of the next); then compound 1.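

In this assay, putting 2-((tert-butoxycarbonyl)amino)ethyl in place of (tert-butoxycarbonyl)amino on a saturated chain carbon, three bonds along the chain from a carbonyl carbon, gives a 1.6-fold higher number from compound 2 to compound 3 (0.19 log units; within the scatter), so this lengthening of the linear chain registers as no real change at this position. The earlier step, a 4.8-fold lower number from compound 1 to compound 2 (0.68 log units; beyond the scatter), therefore does not carry on along the chain: a pattern of lower numbers with each addition of chain length fails at compound 3, and that earlier step also took a branched group to a linear one, so it cannot be read as an effect of length alone. No supporting data are available to account for this result.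

On these data alone, all three compounds end in the same (tert-butoxycarbonyl)amino group, so how a free amine or a carboxylic acid at the end of the chain would read in this assay remains open. Also open, as far as these compounds go, is whether a longer chain than that of compound 3 would stay within the scatter of compound 3 or move beyond it, and in which direction.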